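From dipropylamino to dibutylamino on compound 1

The compounds below may be only part of what the source reports. "The series", "measured", "known", "first", "only" and "open" are said of these compounds alone.

Going by the values given here, in a functional assay (aorta) with Rattus norvegicus as the target (on this read-out higher numbers stand for weaker inhibition and lower numbers for stronger inhibition), compound 1 `CCCN(CCC)CCCOc1ccc(S(=O)(=O)c2c(C)cn3ccccc23)cc1` gives 957 nM, the higher of the two numbers so far, while compound 2 `CCCN(CCC)CCCOc1ccc(S(=O)(=O)c2c(C(C)C)cn3ccccc23)cc1` gives 102 nM. Compound 3 `CCCCN(CCCC)CCCOc1ccc(S(=O)(=O)c2c(C)cn3ccccc23)cc1` keeps the core of compound 1 and alters only the amine: dibutylamino in place of dipropylamino on a saturated chain carbon, three bonds along the chain from an oxygen on an aromatic ring. Among the compounds with values here, no measured step touches this place. Within the data shown here, the only guide comes from another place, a 9.4-fold lower number from compound 1 to compound 2 (0.97 log units; beyond the scatter), where isopropyl replaced methyl on an aromatic carbon. A smaller move the same way is therefore expected in this assay, though on thin evidence. The expected step is a 2.3-fold lower number from compound 1 to compound 3 (0.36 log units; beyond the scatter). For compound 3 the estimated value is 420 nM, with a range of 130 nM to 1300 nM.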

Compound 3, half-maximal inhibitory concentration: 162 nM
Compound 3: the middle estimate sits 2.6-fold (0.41 log units) above what was measured, within the range that was stated.
By their numbers in this assay, from the lowest: compounds 2 and 3 (each within the scatter of the next); then compound 1.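

In this assay, the amine at the end of the chain proves to be a place that responds, not a passive part of the molecule: with the core of compound 1 unchanged, dibutylamino in place of dipropylamino gives a 5.9-fold lower number from compound 1 to compound 3 (0.77 log units; beyond the scatter). Nothing available explains why the number falls at this position.

From the compounds shown here alone, whether a longer group such as dipentylamino would lower the number further, or a ring amine such as piperidine would serve as well, stays open. So does whether dibutylamino and isopropyl would add up when combined in one compound.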